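Working notes on the series: the step to compound 4

The source may hold more compounds than are shown below. What is called first, only, known or untested is meant among the compounds shown, and "the series" means these compounds.

Measured compounds in a functional assay on PC-3 cells (Homo sapiens) for cytotoxicity, read by MTT assay, with a stated time of 72 h; a lower number here means a stronger inhibitor, a higher number a weaker inhibitor:
compound 1 `COc1ccc(S(=O)(=O)c2nc3ccccc3nc2Nc2cccc(N)c2)cc1` gives 8600 nM
compound 2 `Nc1cccc(Nc2nc3ccccc3nc2S(=O)(=O)c2ccc(Br)cc2)c1` gives 9010 nM
compound 3 `COc1cc(Nc2nc3ccccc3nc2S(=O)(=O)c2ccc(F)cc2)cc(OC)c1` gives 4530 nM

Compound 3 carries the smallest of the three numbers, but its gaps to compound 1 and to compound 2 both sit within the usual scatter, so no ranking among the three is supported. Within the data shown here, the only step measured in this assay, a 1.0-fold higher number from compound 1 to compound 2 (0.02 log units; within the scatter), concerns the group on the sulfonyl-bearing ring and leaves the aniline part untouched.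

Compound 4 `Nc1cccc(Nc2nc3ccccc3nc2S(=O)(=O)c2ccc(F)cc2)c1` differs from compound 3 in that part: 3-aminophenyl in place of 3,5-dimethoxyphenyl on a nitrogen on an aromatic ring. Among the measured compounds shown here, no measured step covers this swap. What the data do show is that, among the compounds that already carry 3-aminophenyl, compound 1 gives 8600 nM and compound 2 gives 9010 nM, and that compound 3 with 3,5-dimethoxyphenyl gives 4530 nM; the difference between those two groups comes with a change elsewhere and cannot be separated out. The expectation is therefore a modest step upward, a 1.7-fold higher number from compound 3 to compound 4 (0.22 log units; within the scatter), not clearly beyond the scatter. Compound 4 is estimated at 7500 nM, with a range from 3500 nM to 16000 nM.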

Compound 4, half-maximal inhibitory concentration: 1980 nM
Compound 4: middle estimate off by 3.8-fold (0.58 log units), on the high side; measured number below the stated range.
By their numbers in this assay, from the lowest: compound 4; then compounds 3, 1 and 2 (each within the scatter of the next).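

In this assay the swap to 3-aminophenyl from 3,5-dimethoxyphenyl gives a 2.3-fold lower number from compound 3 to compound 4 (0.36 log units; beyond the scatter) with fluoro held on the other ring, so the group on this nitrogen on an aromatic ring can shift the number beyond the scatter. With 3-aminophenyl held, a 4.6-fold lower number from compound 2 to compound 4 (0.66 log units; beyond the scatter) and a 4.3-fold lower number from compound 1 to compound 4 (0.64 log units; beyond the scatter) set fluoro apart from bromo and methoxy on an aromatic carbon, while a 1.0-fold higher number from compound 1 to compound 2 (0.02 log units; within the scatter) separates neither of those two groups from the other. No measured evidence accounts for any of these steps.

From the compounds shown here alone, the swap on the nitrogen rests on a single pair, so whether it holds with bromo or methoxy in place of fluoro stays open. Also open, going by these compounds, is how chloro or trifluoromethyl in place of fluoro, or a hydroxyl or acetamide in place of the amine, would read.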